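Ethylcarbamoyl in place of the sulfur-bearing group: compound 4

A few compounds are considered here, and "the series" means these few. Any claim that something is new, unique, unknown or untested is made for them only; others in the source may bear on it.

Working notes on inhibition in an assay for inhibition of Nitric oxide synthase, inducible (Homo sapiens), read by scintillation counting, with a stated time of 30 min, tested at 1 mM; on this read-out higher numbers stand for more inhibition at the one concentration tested (going by the name of the read-out) and lower numbers for less inhibition:
compound 1, `CNC(=S)NCCC(O)c1ccccc1N`, gives 20.7%
compound 2, `CCNC(=S)NCCC(O)c1ccccc1N`, gives 19.4%
compound 3, `CCCNC(=S)NCCC(O)c1ccccc1N`, gives 31.1%

Compound 3 stands highest of the three numbers. Its nearest neighbour is compound 1, the step being a number 10.4 percentage points higher from compound 1 to compound 3 (beyond the scatter); the furthest is compound 2, the step being a number 11.7 percentage points higher from compound 2 to compound 3 (beyond the scatter). Between the two lower compounds the step is a number 1.3 percentage points lower from compound 1 to compound 2 (within the scatter), so only compound 3 separates itself from the others.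

Compound 4, `CCNC(=O)NCCC(O)c1ccccc1N`, differs from compound 3 by a group of 5 heavy atoms (3 carbon, 1 nitrogen, 1 oxygen; no ring) in place of a group of 6 heavy atoms (4 carbon, 1 nitrogen, 1 sulfur; no ring), on an amine nitrogen. Within the data shown here, none of the measured steps touches this part of the structure: all three alter only the saturated chain on the other nitrogen and keep the sulfur-bearing group unchanged. Among the measured compounds shown here, there is thus no measured step that bears directly on the exchange of sulfur for oxygen, and the steps that do exist are modest at most. For the measured compounds named here, with nothing to point in either direction, no step beyond the scatter is expected; the estimate is set slightly below compound 3 because compound 3 carries the single highest number, 31.1%, and a return toward the other two values cannot be ruled out.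

Compound 4 is expected to give 26% in this assay, within 10% to 42%. The expected step is a number 5.1 percentage points lower from compound 3 to compound 4 (within the scatter), inside the usual scatter.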

Compound 4, a percentage reported as inhibition, at one concentration (the size of the read-out at that concentration, not a potency): 18.3%
Beside the measured number, compound 4's estimate is 7.7 percentage points above it; low and high end bracket the measured number.
By their numbers in this assay, from the lowest: compounds 4, 2 and 1 (each within the scatter of the next); then compound 3.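

Notes on the exchange on the amine nitrogen, in this assay: with ethylcarbamoyl entering in place of the sulfur-bearing group of 5 heavy atoms, the change gives a number 1.1 percentage points lower from compound 2 to compound 4 (within the scatter) and is the first reading of oxygen for sulfur with the count of heavy atoms unchanged, so at this size the exchange shows no effect that can be told from the scatter. Among these compounds, the other two exchanges differ in the count of heavy atoms as well as in the atom exchanged: one gives a number 2.4 percentage points lower from compound 1 to compound 4 (within the scatter) and stays within the scatter, while the other gives a number 12.8 percentage points lower from compound 3 to compound 4 (beyond the scatter) and goes beyond it, which leaves compound 3 as the only compound set apart from the rest, though this step alone cannot separate the loss of sulfur from the shorter chain. No supporting measurement is available to explain any of these steps.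

From the compounds shown here alone, whether propylcarbamoyl would hold the number of compound 3 or fall back to the level of compound 4 stays open, and this is the pairing that would show if the higher reading depends on sulfur. Also open, going by these compounds, is how a longer chain such as butyl, or a guanidine in place of the carbonyl, would read at this position.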